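Linker change carried onto the second core: notes for compound 4

The compounds below may be only part of what the source reports. "The series", "measured", "known", "first", "only" and "open" are said of these compounds alone.

Compound 1 `C#Cc1cccc(Nc2ncnc3cc(OCCCCCn4ccnc4[N+](=O)[O-])c(OC)cc23)c1` is the reference point of the set. In a functional assay on A549 cells (Homo sapiens) for inhibition, read by sulforhodamine B assay, with a stated time of 72 h (a higher number here means a weaker inhibitor, a lower number a stronger inhibitor), compound 1 gives 770 nM. Compound 2 `C#Cc1cccc(Nc2ncnc3cc(OCCOCCn4ccnc4[N+](=O)[O-])c(OC)cc23)c1` carries 2-(2-nitro-1H-imidazol-1-yl)ethoxy in place of 3-(2-nitro-1H-imidazol-1-yl)propyl on a saturated chain carbon, two bonds along the chain from an oxygen on an aromatic ring; in this assay compound 2 gives 9770 nM, and the step is a 13-fold higher number from compound 1 to compound 2 (1.10 log units; beyond the scatter). Compound 3 `COc1cc2c(Nc3cccc(Br)c3)ncnc2cc1OCCCCCn1ccnc1[N+](=O)[O-]` differs from compound 1 in the core by bromo in place of ethynyl on an aromatic carbon; in this assay compound 3 gives 8780 nM, and that step is an 11-fold higher number from compound 1 to compound 3 (1.06 log units; beyond the scatter). Compound 2 and compound 3 show values within the scatter of each other.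

Compound 4 `COc1cc2c(Nc3cccc(Br)c3)ncnc2cc1OCCOCCn1ccnc1[N+](=O)[O-]` is not yet measured. It differs from compound 3 by 2-(2-nitro-1H-imidazol-1-yl)ethoxy in place of 3-(2-nitro-1H-imidazol-1-yl)propyl on a saturated chain carbon, two bonds along the chain from an oxygen on an aromatic ring, the same kind of change as that from compound 1 to compound 2, now made on the core of compound 3; the place of the change is described in the same words for both pairs.

The step in this assay is expected to be a 6.8-fold higher number from compound 3 to compound 4 (0.83 log units; beyond the scatter), set beside the measured 13-fold higher number from compound 1 to compound 2 (1.10 log units; beyond the scatter). This rests on one measured instance only, and on compound 3 already standing at 8780 nM, so a somewhat smaller step is expected. Compound 4 is estimated at 60000 nM, within 15000 nM to 200000 nM.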

Compound 4, half-maximal inhibitory concentration: 13000 nM
Estimate against measurement, compound 4: 4.6-fold (0.66 log units) above; the whole stated range lies above it.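

The linker change does not carry over from one core to the other in this assay, where on the core of compound 3 it gives a 1.5-fold higher number from compound 3 to compound 4 (0.17 log units; within the scatter), and the two steps differ: the same change on two cores in this assay, a 13-fold higher number (1.10 log units; beyond the scatter) from compound 1 to compound 2 and a 1.5-fold higher number (0.17 log units; within the scatter) from compound 3 to compound 4, 8.6-fold (0.93 log units) apart, beyond the scatter of two such steps

Read the other way, bromo in place of ethynyl gives a 1.3-fold higher number from compound 2 to compound 4 (0.12 log units; within the scatter) once the 2-(2-nitro-1H-imidazol-1-yl)ethoxy chain is present, so that change does not carry over either: the same change on two cores in this assay, an 11-fold higher number (1.06 log units; beyond the scatter) from compound 1 to compound 3 and a 1.3-fold higher number (0.12 log units; within the scatter) from compound 2 to compound 4, 8.6-fold (0.93 log units) apart, beyond the scatter of two such steps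

Each single change away from compound 1 therefore loses much, while the second change adds nothing beyond the scatter; this rests on one set of four compounds and does not show why the steps differ or whether the same holds on any other core.

Open, going by these compounds, is whether a longer chain, or a chain holding an amine, keeps the value of compound 1 with ethynyl on the aromatic carbon. Also open, on these data alone, is whether chloro on that carbon behaves like bromo or like ethynyl.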